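Nitro removal from compound 2: expected effect on potency

A few compounds are considered here, and "the series" means these few. Any claim that something is new, unique, unknown or untested is made for them only; others in the source may bear on it.

Measured in a functional assay on the whole organism with Oryctolagus cuniculus as the target; a higher number here means a weaker inhibitor, a lower number a stronger inhibitor:
- compound 1 `CO/C(O)=C1\C(C)=Nc2ccccc2SC1c1ccccc1[N+](=O)[O-]`: 300 nM
- compound 2 `CO/C(O)=C1\C(C)=Nc2ccccc2SC1c1ccc([N+](=O)[O-])cc1`: 3000 nM

Of the two measured compounds, compound 2 has the higher number at 3000 nM, which makes it the weaker inhibitor. Compound 1 gives 300 nM, a gap beyond the scatter.

Compound 3 `CO/C(O)=C1\C(C)=Nc2ccccc2SC1c1ccccc1` is still to be measured in this assay. It differs from compound 2 as follows: hydrogen in place of nitro on an aromatic carbon. In words, hydrogen stands in place of nitro on an aromatic carbon, para to a large group.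

Among the compounds with values here, no measured pair shows this change, so any expectation is loose and the range is kept wide. The expected move is a 1.2-fold lower number from compound 2 to compound 3 (0.08 log units; within the scatter), slightly toward a lower number and not expected to exceed the scatter. For compound 3 the estimated value is 2500 nM, with an expected range of 600 nM to 10000 nM.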

Compound 3, half-maximal inhibitory concentration: 1700 nM
For compound 3 the middle estimate is 1.5-fold (0.17 log units) above the measured one; measured number inside the range.
By their numbers in this assay, from the lowest: compound 1; then compounds 3 and 2 (each within the scatter of the next).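

In this assay, hydrogen in place of nitro para to a large group gives a 1.8-fold lower number from compound 2 to compound 3 (0.25 log units; within the scatter) and so leaves the read-out within the scatter; at this place, the nitro group shows no measurable contribution. The same exchange at the nitro place of compound 1 gives a 5.7-fold higher number from compound 1 to compound 3 (0.75 log units; beyond the scatter) and lies beyond the scatter, so in this small set the outcome of losing nitro depends on where on the ring the nitro group stood. No measured data here bear on a cause for this contrast.

Still open, going by these compounds, is whether an amine or a methoxy group para to a large group would also stay within the scatter of hydrogen. Also open, on these data alone, is whether a chlorine or an amine at the nitro place of compound 1 would keep its lower number.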